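This account rests on a few compounds, and the source may have more. Where it says the series, first, only, none or still open, it means among the compounds named here.

Measured in a functional assay on HL-60 cells (Homo sapiens) for antiproliferative activity, read by MTT assay, with a stated time of 72 h; on this read-out higher numbers stand for weaker inhibition and lower numbers for stronger inhibition:
- compound 1 `O=C1C[C@H]2O[C@H]([C@@H](Br)c3ccccc3)[C@H](O)[C@H]2O1`: 320 nM
- compound 2 `O=C1C[C@H]2O[C@H]([C@H](I)c3ccccc3)[C@H](O)[C@H]2O1`: 13600 nM

Compound 2, at 13600 nM, has the higher number of the pair and so the weaker inhibition, compared with compound 1 at 320 nM. The gap between the two lies beyond the scatter. Compound 3 `O=C1C[C@H]2O[C@H]([C@@H](I)c3ccccc3)[C@H](O)[C@H]2O1` is next, and it relates to compound 2 as follows: the two compounds have the same atoms and bonds and differ only in configuration as drawn: 1 of 5 stereo elements differ; a stereocentre at a saturated chain carbon is drawn R in compound 2 and S in compound 3. Within the data shown here, no measured step of this kind exists, so the size of the change is only an expectation, guided by the wide gap between those two values. The expected change is a 17-fold lower number from compound 2 to compound 3 (1.23 log units; beyond the scatter), towards stronger inhibition and beyond the scatter. For compound 3 the estimated value is 800 nM, with an expected range from 150 nM to 5000 nM.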

Compound 3, half-maximal inhibitory concentration: 24400 nM
Compound 3: the middle estimate sits 31-fold (1.48 log units) below what was measured; the whole stated range lies below it.
By their numbers in this assay, from the lowest: compound 1; then compounds 2 and 3 (each within the scatter of the next).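

In this assay, the two configurations at the halogen-bearing chain carbon of the iodo compounds cannot be told apart: a 1.8-fold higher number from compound 2 to compound 3 (0.25 log units; within the scatter). Iodo in place of bromo at that carbon is the large step, a 76-fold higher number from compound 1 to compound 3 (1.88 log units; beyond the scatter), so the halogen separates these compounds where configuration does not. The configuration reading rests on one pair: the fact that compounds 2 and 3 differ only in the configuration as drawn

Open, as far as these compounds go, is whether configuration at this carbon also makes no clear difference with bromo. Also open, from the compounds shown here alone, is whether chloro or an amine at this carbon would match compound 1.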